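The source may hold more compounds than are shown below. What is called first, only, known or untested is meant among the compounds shown, and "the series" means these compounds.

Compound 1 `O=S(=O)(c1ccc(F)c(Cl)c1)c1cnc2cc(F)ccc2c1-c1ccc(F)cc1` gives 21 nM in a functional assay on cells for negative allosteric modulation of metabotropic glutamate receptor 5 (Homo sapiens), read by fluorescence and calcium flux, with a stated time of 20 min; a higher number here means a weaker inhibitor, a lower number a stronger inhibitor.
Compound 2 `O=S(=O)(c1cccc(F)c1)c1cnc2c(F)cccc2c1-c1ccc(F)cc1` gives 69 nM in this assay.
Compound 3 `O=S(=O)(c1ccc(F)c(Cl)c1)c1cnc2cc(F)ccc2c1-c1ccc(Cl)cc1` gives 27 nM in this assay.

Among these three numbers compound 3 stands second highest. For the measured compounds named here, its nearest neighbour is compound 1, which lies below it by a 1.3-fold higher number from compound 1 to compound 3 (0.11 log units; within the scatter) read backwards, a gap within the scatter; its furthest is compound 2, whose value is higher than that of compound 3 by a gap beyond the scatter, though the two differ in several places and no single step connects them.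

Compound 4 `O=S(=O)(c1ccc(F)c(F)c1)c1cnc2cc(F)ccc2c1-c1ccc(Cl)cc1` has not yet been measured. It differs from compound 3 by fluoro in place of chloro on an aromatic carbon, that is, the sulfonyl-bearing ring changes from 3-chloro-4-fluorophenyl to 3,4-difluorophenyl. Going by the values given here, the one step that bears on this is the chloro for fluoro swap between compound 1 and compound 3, which read a 1.3-fold higher number from compound 1 to compound 3 (0.11 log units; within the scatter) and stayed within the scatter, although it sat on the other aromatic ring. Among the compounds with values here, no step on this ring itself is available. The expectation is therefore a small change or none beyond the scatter, a 1.5-fold higher number from compound 3 to compound 4 (0.17 log units; within the scatter). Compound 4 is estimated at 40 nM, with a range from 15 nM to 110 nM.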

Compound 4, half-maximal inhibitory concentration: 22 nM
Compound 4: the middle estimate sits 1.8-fold (0.26 log units) above what was measured; measured number inside the range.
By their numbers in this assay, from the lowest: compounds 1, 4 and 3 (each within the scatter of the next); then compound 2.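

On the ring carrying the sulfonyl group, at the carbon that holds the chloro group in compound 3, exchanging chloro for fluoro leaves the result in this assay unchanged within the scatter (a 1.2-fold lower number from compound 3 to compound 4 (0.09 log units; within the scatter)). The earlier swap of the same two halogens sat on the other aromatic ring (a 1.3-fold higher number from compound 1 to compound 3 (0.11 log units; within the scatter)), so among these compounds the exchange now reads as tolerated at two separate places, and this is the first direct reading at this position. Nothing shown explains why the two halogens read alike here.

Both groups tested at this position are single halogen atoms, so these compounds leave open how it responds to something quite different, such as a methoxy group, an amine or a longer alkyl chain. They also leave open whether the same exchange would read alike on a different core.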